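The compounds below may be only part of what the source reports. "The series", "measured", "known", "first", "only" and "open" are said of these compounds alone.

Compound 1 `COC(=O)C1=C(C)NC(=O)NC1c1cccs1`: 6%
Compound 2 `CC1=C(C(=O)SC(C)C)C(c2cccs2)NC(=O)N1`: 1%

Both compounds were tested in an assay on membranes from CHO cells for displacement of a labelled ligand from adenosine receptor A1 (Homo sapiens), read by scintillation counting, with a stated time of 60 min, tested at 1 uM; a lower number here means less inhibition, a higher number more inhibition at the concentration tested (going by the name of the read-out). Compound 2 holds the lowest of the two numbers, and its nearest neighbour is compound 1; the step of a number 5 percentage points lower from compound 1 to compound 2 (within the scatter) is within the scatter, so the two results cannot be told apart. Compound 3 `CC1=C(C(=O)OC2CCC2)C(c2cccs2)NC(=O)N1` keeps the shared core and differs from compound 2 in one place: cyclobutyloxy in place of isopropylsulfanyl on a carbonyl carbon. Going by the values given here, the only measured step that bears on this is the one from compound 1 to compound 2, which also exchanged the group on that carbonyl carbon, and it stayed within the scatter. On that basis the exchange to cyclobutyloxy is expected to bring no step beyond the scatter, a number 3 percentage points higher from compound 2 to compound 3 (within the scatter), in this assay . Compound 3 is therefore estimated at 4%, with a range from 0% to 15%.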

Compound 3, a percentage reported as inhibition, at one concentration (the size of the read-out at that concentration, not a potency): 24%
Estimate against measurement, compound 3: 20 percentage points below; measured number outside the range, above it.
By their numbers in this assay, from the lowest: compounds 2 and 1 (each within the scatter of the next); then compound 3.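

The group on this carbonyl carbon can change the result in this assay, which the earlier exchange of methoxy for isopropylsulfanyl did not show. Cyclobutyloxy in place of isopropylsulfanyl gives a number 23 percentage points higher from compound 2 to compound 3 (beyond the scatter), a modest step beyond the scatter. Cyclobutyl in place of methyl on the oxygen next to the carbonyl group gives a number 18 percentage points higher from compound 1 to compound 3 (beyond the scatter), so the rise appears against both neighbours and does not depend on which of the two earlier groups it replaces.

On these data alone, what a butyloxy chain, a cyclopentyloxy ring or an amine on that carbonyl carbon would give remains open, so it cannot yet be said whether the four-membered ring itself matters. No supporting measurement is available to explain the rise.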